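Branching the Ester Group: Expected Effect on Receptor Binding

A few compounds are considered here, and "the series" means these few. Any claim that something is new, unique, unknown or untested is made for them only; others in the source may bear on it.

Measured compounds:
compound 1 `COC(=O)C1=C(C)N(C)C(=O)NC1c1ccco1`: 31%
compound 2 `CCCOC(=O)C1=C(C)N(C)C(=O)NC1c1ccco1`: 23%
compound 3 `CC1=C(C(=O)OCC(C)C)C(c2ccco2)NC(=O)N1C`: 4%

In an assay on membranes from HEK293 cells for displacement of a labelled ligand from adenosine receptor A2b (Homo sapiens), read by scintillation counting, with a stated time of 30 min, tested at 1 uM (a higher number here means more inhibition at the concentration tested (going by the name of the read-out), a lower number less inhibition), compound 1 gives 31%, compound 2 gives 23% and compound 3 gives 4%. Compound 3 stands lowest of the three: a number 27 percentage points lower from compound 1 to compound 3 (beyond the scatter) and a number 19 percentage points lower from compound 2 to compound 3 (beyond the scatter) are both beyond the scatter, whereas a number 8 percentage points lower from compound 1 to compound 2 (within the scatter) is within it. Compound 4 `CC1=C(C(=O)OC(C)(C)C)C(c2ccco2)NC(=O)N1C` differs from compound 3 by tert-butyl in place of isobutyl on an oxygen next to a carbonyl group. The two steps that bear on this, a number 27 percentage points lower from compound 1 to compound 3 (beyond the scatter) and a number 19 percentage points lower from compound 2 to compound 3 (beyond the scatter), both went downward when the group on that oxygen grew or branched. A further branching is therefore expected to lower inhibition at most a little, since compound 3 already sits near the bottom of the scale. Compound 4 is expected to give 3%, between 0% and 12%, which is expected to mean a number 1 percentage points lower from compound 3 to compound 4 (within the scatter).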

Compound 4, a percentage reported as inhibition, at one concentration (the size of the read-out at that concentration, not a potency): 26%
Beside the measured number, compound 4's estimate is 23 percentage points below it, and the stated range ends below it.
By their numbers in this assay, from the lowest: compound 3; then compounds 2, 4 and 1 (each within the scatter of the next).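

Isobutyl and tert-butyl carry the same four carbons on this oxygen, yet exchanging one for the other gives a number 22 percentage points higher from compound 3 to compound 4 (beyond the scatter) in this assay, so the drop seen at compound 3 does not simply continue with further branching. The propyl and methyl esters cannot be separated from the tert-butyl ester, with a number 3 percentage points higher from compound 2 to compound 4 (within the scatter) and a number 5 percentage points lower from compound 1 to compound 4 (within the scatter). Nothing available explains the difference between the two butyl groups. Open, going by these compounds, is how a longer chain such as hexyl, or a benzyl group, would fare on this oxygen.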